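Swapping Methoxy for Chloro on a Biaryl Thiophene Amidine

The source may hold more compounds than are shown below. What is called first, only, known or untested is meant among the compounds shown, and "the series" means these compounds.

Three compounds built on one shared core were tested in a functional assay on OVCAR-8 cells (Homo sapiens) for inhibition, read by sulforhodamine B assay, with a stated time of 48 h; on this read-out lower numbers stand for stronger inhibition of growth and higher numbers for weaker inhibition of growth. Compound 1 `COc1ccc(-c2ccc(-c3ccc(C(=N)N)cc3)s2)cc1` gives 321 nM, the lowest number of the three. Compound 3 `COc1cc(OC)cc(-c2ccc(-c3ccc(C(=N)N)cc3)s2)c1` gives 2480 nM, a gap from compound 1 that lies beyond the usual scatter, and compound 2 `N=C(N)c1ccc(-c2ccc(-c3ccccc3)s2)cc1F` gives 11300 nM, further away still. For the measured compounds named here, no measured pair differs in just one place, so no single change can yet be read as a step on its own. Compound 4 `N=C(N)c1ccc(-c2ccc(-c3ccc(Cl)cc3)s2)cc1` has not been measured; it differs from compound 1 in chloro in place of methoxy on an aromatic carbon. Going by the values given here, no measured step shows how this change acts on the read-out; a step of a 1.6-fold higher number from compound 1 to compound 4 (0.19 log units; within the scatter) is expected, small and likely within the scatter. Compound 4 is estimated at 500 nM, within 150 nM to 2000 nM.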

Compound 4, concentration for 50% growth inhibition: 223 nM
Estimate against measurement, compound 4: 2.2-fold (0.35 log units) above, within the range that was stated.
By their numbers in this assay, from the lowest: compounds 4 and 1 (each within the scatter of the next); then compound 3; then compound 2.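

In this assay, for the compounds shown here, this is the first comparison in the set that changes only one place: a 1.4-fold lower number from compound 1 to compound 4 (0.16 log units; within the scatter), with chloro in place of methoxy on an aromatic carbon, para to a large group. The step shows that this position accepts either group with no change beyond the scatter, so the oxygen of methoxy is not needed to keep the number in this range. No measurement here explains why the two groups read alike.

Still open, from the compounds shown here alone, is how an amine, a carboxylic acid or a longer chain such as butoxy would read at this same position.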